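The source may hold more compounds than are shown below. What is called first, only, known or untested is meant among the compounds shown, and "the series" means these compounds.

Compound 1 `O=C1NCCN1c1ccc(S(=O)(=O)Nc2ccc(F)c(F)c2)cc1`: 350 nM
Compound 2 `O=C1NCCN1c1ccc(S(=O)(=O)Nc2cccc(Cl)c2)cc1`: 55 nM
Compound 3 `Cc1ccccc1NS(=O)(=O)c1ccc(N2CCNC2=O)cc1`: 200 nM

All three were tested in a functional assay on HT-29 cells (Homo sapiens) for antiproliferative activity, read by sulforhodamine B assay, with a stated time of 48 h; on this read-out higher numbers stand for weaker inhibition and lower numbers for stronger inhibition. There, compound 3 gives 200 nM, a number that stands clearly apart from only one of the other two: the steps read a 1.8-fold lower number from compound 1 to compound 3 (0.24 log units; within the scatter) and a 3.6-fold higher number from compound 2 to compound 3 (0.56 log units; beyond the scatter).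

Compound 4 `COc1ccccc1NS(=O)(=O)c1ccc(N2CCNC2=O)cc1` has not yet been measured. It differs from compound 3 by methoxy in place of methyl on an aromatic carbon, ortho to a large group, so that 2-methylphenyl becomes 2-methoxyphenyl.

Going by the values given here, no measured step tests this exchange directly. The closest evidence comes from swaps of the whole aryl group on the sulfonamide nitrogen, of which the largest is a 6.4-fold lower number from compound 1 to compound 2 (0.80 log units; beyond the scatter). Since this change is smaller than those swaps, no step beyond the scatter is expected in this assay, and the data favour no firm direction. The expected step is a 1.2-fold lower number from compound 3 to compound 4 (0.07 log units; within the scatter). For compound 4 the estimated value is 170 nM, with an expected range from 50 nM to 600 nM.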

Compound 4, half-maximal inhibitory concentration: 550 nM
Beside the measured number, compound 4's estimate is 3.2-fold (0.51 log units) below it; low and high end bracket the measured number.
By their numbers in this assay, from the lowest: compound 2; then compounds 3, 1 and 4 (each within the scatter of the next, the first and the last beyond it).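

Unlike the earlier steps, which swap the whole aryl group on the sulfonamide nitrogen, this one changes a single group on an aromatic carbon, ortho to a large group, and in this assay it gives a 2.8-fold higher number from compound 3 to compound 4 (0.44 log units; beyond the scatter) from that one exchange alone. Against the other two aryl groups, 2-methoxyphenyl shows a 10-fold higher number from compound 2 to compound 4 (1.00 log units; beyond the scatter) as the widest gap in the set and a 1.6-fold higher number from compound 1 to compound 4 (0.20 log units; within the scatter) that does not separate the two. Nothing measured here bears on the reason for the step from methyl to methoxy.

The compounds shown leave open whether a hydroxy, an ethoxy or a chlorine on this same aromatic carbon would read like methyl or like methoxy. Also open, from the compounds shown here alone, is how a methoxy group would read at the place that chlorine holds in 3-chlorophenyl.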